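Swapping 4-chlorophenyl for thiophen-2-yl on the sulfonyl sulfur

The source may hold more compounds than are shown below. What is called first, only, known or untested is meant among the compounds shown, and "the series" means these compounds.

In a functional assay on MCF7 cells (Homo sapiens) for antiproliferative activity, read by sulforhodamine B assay, with a stated time of 72 h (on this read-out lower numbers stand for stronger inhibition and higher numbers for weaker inhibition), compound 1 `Cc1ccc(S(=O)(=O)Nc2cc(SCCC(=O)N[C@@H](CC(C)C)B(O)O)c(O)c3ccccc23)cc1` gives 6940 nM, compound 2 `CC(C)C[C@H](NC(=O)CCSc1cc(NS(=O)(=O)c2ccccc2)c2ccccc2c1O)B(O)O` gives 7460 nM and compound 3 `CC(C)C[C@H](NC(=O)CCSc1cc(NS(=O)(=O)c2ccc(Cl)cc2)c2ccccc2c1O)B(O)O` gives 6910 nM. Compound 3 thus stands level with the other two, since its steps to both lie within the scatter.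

The next structure is compound 4 `CC(C)C[C@H](NC(=O)CCSc1cc(NS(=O)(=O)c2cccs2)c2ccccc2c1O)B(O)O`, which carries thiophen-2-yl in place of 4-chlorophenyl on a sulfonyl sulfur.

Among the measured compounds shown here, no measured step replaces the whole group on the sulfonyl sulfur. The closest evidence is the exchange of methyl, hydrogen and chloro on an aromatic carbon of that group: a 1.1-fold higher number from compound 1 to compound 2 (0.03 log units; within the scatter), a 1.0-fold lower number from compound 1 to compound 3 (0.00 log units; within the scatter) and a 1.1-fold lower number from compound 2 to compound 3 (0.03 log units; within the scatter), each within the scatter. The change to compound 4 is larger than any of these, so the range is kept wide. No shift beyond the scatter is expected in this assay, and no direction is favoured.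

The expected step is a 1.0-fold higher number from compound 3 to compound 4 (0.01 log units; within the scatter). For compound 4 the estimated value is 7000 nM, with an expected range of 3500 nM to 13000 nM.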

Compound 4, half-maximal inhibitory concentration: 6470 nM
Beside the measured number, compound 4's estimate is 1.1-fold (0.03 log units) above it; low and high end bracket the measured number.
By their numbers in this assay, from the lowest: compounds 4, 3, 1 and 2 (each within the scatter of the next).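

In this assay the exchange now reaches the whole group on the sulfonyl sulfur, not only a substituent on its aromatic carbon: the thiophen-2-yl change gives a 1.1-fold lower number from compound 3 to compound 4 (0.03 log units; within the scatter) and a 1.2-fold lower number from compound 2 to compound 4 (0.06 log units; within the scatter) and a 1.1-fold lower number from compound 1 to compound 4 (0.03 log units; within the scatter) on the same read-out. The position therefore accepts a five-membered aromatic ring with one hetero atom as readily as the six-membered carbon rings, and neither losing the chlorine nor gaining a hydrogen-bond acceptor moves the number beyond the scatter. No measurement on these compounds accounts for this flat response.

Still open, going by these compounds, is whether the position stays level with an amine or a carboxylic acid on the ring, or with a longer chain in place of the ring. On these data alone, all four compounds share the rest of the structure, so the contribution of the remaining parts stays unknown.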